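This account rests on a few compounds, and the source may have more. Where it says the series, first, only, none or still open, it means among the compounds named here.

In an ADME assay on HUVEC cells (Homo sapiens) for inhibition, read by CCK-8 assay, with a stated time of 24 h, in the presence of a further agent that is not named here (on this read-out higher numbers stand for weaker inhibition and lower numbers for stronger inhibition), compound 1 `Cc1ccccc1-n1cc(-c2ccc(/C=C3\C(=O)Nc4ccccc43)cc2)nn1` gives 14700 nM and compound 2 `O=C1Nc2ccccc2/C1=C/c1ccc(-c2cn(-c3ccccc3F)nn2)cc1` gives 19300 nM, and a 1.3-fold higher number from compound 1 to compound 2 (0.12 log units; within the scatter) leaves the two within the scatter. Compound 3 `O=C1Nc2ccccc2/C1=C/c1ccc(-c2cn(-c3cccc(Cl)c3)nn2)cc1` gives > 20000 nM, which is a limit of the assay and not a number. It therefore stands at the limit of > 20000 nM in this assay, at which 1 of the 3 values shown sits.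

Compound 4 `N#Cc1cccc(-n2cc(-c3ccc(/C=C4\C(=O)Nc5ccccc54)cc3)nn2)c1` differs from compound 3 in one place, with cyano in place of chloro on an aromatic carbon, turning 3-chlorophenyl into 3-cyanophenyl. Going by the values given here, no measured step makes this exchange itself. The closest evidence comes from changes to the same aryl group, an at least 1.3-fold higher number from compound 1 to compound 3 (0.13 log units; that floor lies within the scatter) and an at least 1.0-fold higher number from compound 2 to compound 3 (0.01 log units; that floor lies within the scatter), and the floors of both lie within the scatter. With only these small steps to go on, no change beyond the scatter is expected in this assay, and another result at the limit would not be a surprise.

The expected step is an at least 1.0-fold lower number from compound 3 to compound 4 (0.02 log units; that floor lies within the scatter). For compound 4, the estimate is 19000 nM, with an expected range from 10000 nM to 35000 nM.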

Compound 4, half-maximal inhibitory concentration: > 20000 nM
Compound 4: no number, only a limit; the forecaster's own chance of this, stated with the estimate: 45%; middle value at least 1.0-fold (0.02 log units) away from the limit.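

In this assay compound 4 gives > 20000 nM, which is a limit of the assay and not a number. The exchange of 3-chlorophenyl for 3-cyanophenyl therefore cannot be read as a step, and this position now carries two different groups at the same limit: the limit of > 20000 nM in this assay, at which 2 of the 4 values shown sit. Against the compounds that carry 2-fluorophenyl and 2-methylphenyl, the only readable floors are an at least 1.0-fold higher number from compound 2 to compound 4 (0.01 log units; that floor lies within the scatter) and an at least 1.3-fold higher number from compound 1 to compound 4 (0.13 log units; that floor lies within the scatter), so neither comparison establishes a difference.

As far as these compounds go, it remains open how an amine or a carboxylic acid at this place would read, and whether any group here would move the number beyond the scatter. From the compounds shown here alone, it is also open how far past the limit compound 3 and compound 4 lie, so no order between chloro and cyano can be given.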